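This account rests on a few compounds, and the source may have more. Where it says the series, first, only, none or still open, it means among the compounds named here.

Measured so far in a physicochemical assay for lipophilicity, read by HPLC, measured as chromatographic lipophilicity, at pH 7.4; a lower number here means a more polar compound, a higher number a more lipophilic compound:
compound 1 `CCC(=O)NCCCO[C@H]1[C@H](C)O[C@@H](O[C@H]2[C@H](C)[C@@H](O[C@@H]3O[C@H](C)C[C@H](N(C)C)[C@H]3O)[C@](C)(O)C[C@@H](C)CN(C)[C@H](C)[C@@H](O)[C@](C)(O)[C@@H](CC)OC(=O)[C@@H]2C)C[C@@]1(C)OC`; compound 1 gives 2.54.
compound 2 `CC[C@H]1OC(=O)[C@H](C)[C@@H](O[C@H]2C[C@@](C)(OC)[C@@H](OCCCNC(=O)C3CCC3)[C@H](C)O2)[C@H](C)[C@@H](O[C@@H]2O[C@H](C)C[C@H](N(C)C)[C@H]2O)[C@](C)(O)C[C@@H](C)CN(C)[C@H](C)[C@@H](O)[C@]1(C)O`; compound 2 gives 2.62.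
compound 3 `CCC(=O)NCCCO[C@@H]1[C@@H](C)N(C)C[C@H](C)C[C@@](C)(O)[C@H](O[C@@H]2O[C@H](C)C[C@H](N(C)C)[C@H]2O)[C@@H](C)[C@H](O[C@H]2C[C@@](C)(OC)[C@@H](O)[C@H](C)O2)[C@@H](C)C(=O)O[C@H](CC)[C@@]1(C)O`; compound 3 gives 2.74.

Compound 1 and compound 2 differ in one place, (cyclobutyl in place of ethyl on a carbonyl carbon). The step in this assay was a number 0.08 log units higher from compound 1 to compound 2 (within the scatter). Compound 3 is built from the same atoms as compound 1, joined differently; the difference between the two cores is not broken down here. The values of compound 3, compound 2 and compound 1 in this assay all lie within the scatter of one another.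

Compound 4 `CC[C@H]1OC(=O)[C@H](C)[C@@H](O[C@H]2C[C@@](C)(OC)[C@@H](O)[C@H](C)O2)[C@H](C)[C@@H](O[C@@H]2O[C@H](C)C[C@H](N(C)C)[C@H]2O)[C@](C)(O)C[C@@H](C)CN(C)[C@H](C)[C@@H](OCCCNC(=O)C2CCC2)[C@]1(C)O` is not yet measured. It differs from compound 3 by cyclobutyl in place of ethyl on a carbonyl carbon, the same change at the same place as the one measured once in this series. Among the compounds with values here, the step in this assay from compound 3 to compound 4 is expected to be a number 0.08 log units higher from compound 3 to compound 4 (within the scatter), resting on the single measured instance, a number 0.08 log units higher from compound 1 to compound 2 (within the scatter), and on nothing else. Compound 4 is therefore estimated at 2.82, with a range from 2.55 to 3.1.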

Compound 4, distribution coefficient: 3.5
The estimate for compound 4 lay 0.68 log units below the measured number, outside the stated range (above it).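

On the core of compound 3, cyclobutyl in place of ethyl on a carbonyl carbon gave a step beyond the scatter in this assay (a number 0.76 log units higher from compound 3 to compound 4 (beyond the scatter)), whereas on the core of compound 1 the same change stayed within the scatter (a number 0.08 log units higher from compound 1 to compound 2 (within the scatter)). The size of this step therefore did not carry from one core to the other, but two instances show this only for this pair of cores and set no rule for the series. No available data explain why the two steps differ.

Still open, on these data alone, is whether cyclohexyl, or a longer chain ending in an amine, in place of ethyl on a carbonyl carbon would also give steps that differ between the two cores. The compounds shown also leave open whether a carboxylic acid at that place would do the same.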